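Aryl swap from compound 3 to compound 4

The compounds below may be only part of what the source reports. "The series", "measured", "known", "first", "only" and "open" are said of these compounds alone.

Measured in a functional assay on MDA-MB-231 cells (Homo sapiens) for inhibition, read by MTT assay, with a stated time of 48 h; a lower number here means a stronger inhibitor of growth, a higher number a weaker inhibitor of growth:
Compound 1 `O=S(=O)(Nc1nccs1)c1ccc(NC(=S)Nc2ccc3ncnc(Nc4cccc(Br)c4)c3c2)cc1`: > 30000 nM (a limit, not a number)
Compound 2 `Fc1ccc(NC(=S)Nc2ccc3ncnc(Nc4cccc(Br)c4)c3c2)cc1Cl`: 300 nM
Compound 3 `FC(F)(F)c1cc(NC(=S)Nc2ccc3ncnc(Nc4cccc(Br)c4)c3c2)ccc1Cl`: 1100 nM

Compound 3, at 1100 nM, has the higher of the two numbers, and its nearest neighbour is compound 2 at 300 nM. The reading for compound 1 is a limit.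

Next comes compound 4 `S=C(Nc1ccc(Br)cc1)Nc1ccc2ncnc(Nc3cccc(Br)c3)c2c1`, with 4-bromophenyl in place of 4-chloro-3-(trifluoromethyl)phenyl on an amide-type nitrogen. Among the compounds with values here, one measured step bears directly on this change, since it exchanges one substituted phenyl for another at the same place: a 3.7-fold higher number from compound 2 to compound 3 (0.56 log units; beyond the scatter). Compound 1 sits at the limit of > 30000 nM in this assay, at which 1 of the 3 values shown sits, so a reading at a limit cannot be ruled out for compound 4.

In this assay, a step no larger than that modest one is expected, probably within the scatter. A lean toward a lower number is a weak call, resting on compound 2 at 300 nM. The expected step is a 1.7-fold lower number from compound 3 to compound 4 (0.23 log units; within the scatter). For compound 4 the estimated value is 650 nM, with an expected range of 200 nM to 2500 nM.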

Compound 4, concentration for 50% growth inhibition: > 30000 nM
Compound 4 gave a limit, no number; the forecaster's own chance of this, stated with the estimate: 5%; middle value at least 46-fold (1.66 log units) away from the limit.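

At the aryl group on this amide-type nitrogen, the exchange to 4-bromophenyl gives an at least 27-fold higher number from compound 3 to compound 4 (1.43 log units; beyond the scatter), and the same comparison from the other measured aryl gives an at least 100-fold higher number from compound 2 to compound 4 (2.00 log units; beyond the scatter), both far larger than a 3.7-fold higher number from compound 2 to compound 3 (0.56 log units; beyond the scatter) in this assay. This position therefore does more than adjust potency among substituted phenyls: compound 2 and compound 3, each with two ring substituents, give numbers, whereas compound 4, with bromo alone, reaches a limit, > 30000 nM. The step between compound 1 and compound 4 joins two limits and cannot be read, and such readings now make up much of this small set: the limit of > 30000 nM in this assay, at which 2 of the 4 values shown sit.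

The compounds shown do not separate an effect of bromo itself from that of having only one ring substituent. An unsubstituted phenyl or a 4-chlorophenyl on the same nitrogen would bear on that question.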